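Shortening the acyl chain in a rotarod series

The compounds below may be only part of what the source reports. "The series", "measured", "known", "first", "only" and "open" are said of these compounds alone.

Compound 2 `CCCCCC(=O)NCC(=O)N(C)c1ccc(Cl)cc1C(=O)c1ccccc1Cl` gives 90 mg/kg in a functional assay on the whole organism with Mus musculus as the target, in the rotarod test (on this read-out lower numbers stand for an effect already at smaller amounts and higher numbers for an effect only at larger amounts of compound), the highest of the two numbers recorded there. Compound 1 `CN(C(=O)CNC(=O)CN)c1ccc(Cl)cc1C(=O)c1ccccc1Cl` gives 27.7 mg/kg in this assay. Compound 3 `CC(=O)NCC(=O)Nc1ccc(Cl)cc1C(=O)c1ccccc1` reaches only the limit > 100 mg/kg in this assay, so no number is available for it. Compound 4 `CC(C)C(=O)NCC(=O)N(C)c1ccc(Cl)cc1C(=O)c1ccccc1Cl` differs from compound 2 by isopropyl in place of pentyl on a carbonyl carbon. Among the compounds with values here, the only measured step in this assay, a 3.2-fold higher number from compound 1 to compound 2 (0.51 log units; beyond the scatter), concerns a different change on the same carbonyl carbon, and nothing measured here addresses pentyl against isopropyl directly. The one step shown is of modest size, and the single limit of > 100 mg/kg in this assay, at which 1 of the 3 values shown sits, adds no number. A modest change is therefore expected, most likely toward a lower number, since the shorter group moves the acyl part back toward that of compound 1 with its 27.7 mg/kg. For compound 4 the estimate is 60 mg/kg, within 25 mg/kg to 150 mg/kg, which means an expected step of a 1.5-fold lower number from compound 2 to compound 4 (0.18 log units; within the scatter).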

Compound 4, dose for half-maximal effect: > 100 mg/kg
Compound 4: no number, only a limit; the forecaster's own chance of this, stated with the estimate: 25%; middle value at least 1.6-fold (0.22 log units) away from the limit.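

Compound 4 gives only a limit in this assay, and it is the second compound shown without a number: the limit of > 100 mg/kg in this assay, at which 2 of the 4 values shown sit. On this carbonyl carbon, the change from pentyl to isopropyl gives an at least 1.1-fold higher number from compound 2 to compound 4 (0.04 log units; that floor lies within the scatter), so no order of the two groups can be stated, and the shorter group does not bring the read-out measurably closer to that of compound 1. The aminomethyl group of compound 1 now stands apart from isopropyl as well as from pentyl, with an at least 3.6-fold higher number from compound 1 to compound 4 (0.55 log units; beyond the scatter).

On these data alone, the true size of the change from pentyl to isopropyl stays open, since compound 4 has no number. Also open, as far as these compounds go, is how a longer chain ending in an amine, or a carboxylic acid, on this carbonyl carbon would compare with the aminomethyl group of compound 1.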